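One ring exchanged on compound 3

This account rests on a few compounds, and the source may have more. Where it says the series, first, only, none or still open, it means among the compounds named here.

- compound 1 `O=C(C1CCCC1)N1N=CCC1c1ccccc1`: 5.4
- compound 2 `CC(C)(C)C(=O)N1N=CCC1c1cc(F)cc(F)c1`: 6.3
- compound 3 `O=C(c1cn[nH]c1)N1CCC(C(=O)N2N=CCC2c2ccccc2)CC1`: 2.1

These three values come from a physicochemical assay for lipophilicity, read by HPLC, measured as chromatographic lipophilicity, at pH 7.4; on this read-out higher numbers stand for higher lipophilicity and lower numbers for lower lipophilicity. Compound 3 stands lowest of the three, and both other compounds lie above it by more than the usual scatter of repeated measurements. Compound 4 `O=C(c1cocn1)N1CCC(C(=O)N2N=CCC2c2ccccc2)CC1` has not been measured yet. It carries 1,3-oxazol-4-yl in place of 1H-pyrazol-4-yl on a carbonyl carbon, and the rest of the molecule stays the same. Among the measured compounds shown here, no two measured compounds differ in only one place, so nothing here sizes this exchange directly, and the expectation is tentative. A modest rise is expected, slightly beyond the scatter: a number 0.50 log units higher from compound 3 to compound 4 (beyond the scatter). For compound 4 the estimated value is 2.6, within a range from 2.1 to 3.1.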

Compound 4, distribution coefficient: 2.9
Beside the measured number, compound 4's estimate is 0.30 log units below it; measured number inside the range.
By their numbers in this assay, from the lowest: compound 3; then compound 4; then compound 1; then compound 2.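

Exchanging 1H-pyrazol-4-yl for 1,3-oxazol-4-yl on a carbonyl carbon gives a number 0.80 log units higher from compound 3 to compound 4 (beyond the scatter) in this assay. Among the compounds shown here, this is the first step here that sizes a single exchange, and it shows that this position responds to a change of ring even though both rings have 5 heavy atoms. The ring that leaves has 1 hydrogen-bond donor and the ring that enters has 0, but nothing measured here explains the step.

From the compounds shown here alone, whether a longer chain or an amine on this carbonyl carbon would shift the number further remains open. So does whether the same exchange gives a similar step on another core.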